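Chalcone-like pyranones against colon cancer cells: a methoxy swap

This account rests on a few compounds, and the source may have more. Where it says the series, first, only, none or still open, it means among the compounds named here.

Measured so far:
compound 1, `Cc1cc(O)c(C(=O)/C=C/c2ccc(Cl)cc2)c(=O)o1`: 87400 nM
compound 2, `COc1ccc(/C=C/C(=O)c2c(O)cc(C)oc2=O)cc1`: > 100000 nM
compound 3, `Cc1cc(O)c(C(=O)/C=C/c2ccccc2Cl)c(=O)o1`: > 100000 nM

All three compounds share a core and were tested in a functional assay on HCT-116 cells (Homo sapiens) for cytotoxicity, read by MTT assay; on this read-out higher numbers stand for weaker inhibition and lower numbers for stronger inhibition. Within the data shown here, compound 1 is the only one that returns a number, giving 87400 nM. For compound 2 the assay reports only a limit, > 100000 nM. The step between them is therefore known only as a floor: an at least 1.1-fold higher number from compound 1 to compound 2 (0.05 log units; that floor lies within the scatter), brought about by methoxy in place of chloro on an aromatic carbon. The floor cannot be sharpened because the limit of > 100000 nM in this assay, at which 2 of the 3 values shown sit, is where the readout stops.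

For compound 3 the assay likewise gives only a limit, > 100000 nM. Compound 3 and compound 1 are built from the same atoms joined differently; the difference between the two cores is not broken down here.

The unmeasured compound 4, `COc1ccccc1/C=C/C(=O)c1c(O)cc(C)oc1=O`, differs from compound 3 by methoxy in place of chloro on an aromatic carbon. Among the measured compounds shown here, this is the same kind of change as the one from compound 1 to compound 2, yet not the same: there the new group sat para to a large group, here it sits ortho to a large group.

Since compound 3 already sits at the limit and the earlier swap, an at least 1.1-fold higher number from compound 1 to compound 2 (0.05 log units; that floor lies within the scatter), did not strengthen inhibition, the step from compound 3 to compound 4 is expected to be a step that the limit leaves unreadable from compound 3 to compound 4. Compound 4 is thus estimated at 150000 nM, most likely reported as a limit once more.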

Compound 4, half-maximal inhibitory concentration: > 100000 nM
Compound 4 ended at the assay's limit; the forecaster's own chance of this, stated with the estimate: 75%; the middle value is on the limit's open side.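

Compound 3 and compound 4 both stop at the assay's limit, so the change from chloro to methoxy between them has no readable size: the limit of > 100000 nM in this assay, at which 3 of the 4 values shown sit.

From the compounds shown here alone, it remains open how far compound 2, compound 3 and compound 4 lie past that limit, and so whether methoxy in place of chloro on an aromatic carbon alters cytotoxicity in these cells at all.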